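Hydroxy for bromo on a hydrazone series: cytotoxicity outlook

The source may report more compounds than this note shows. Statements on the series, on what has been measured and on what is new or still open speak of the compounds shown alone.

The series shares one core. Compound 1 `O=C(N/N=C/c1ccccc1)c1cnccn1` carries no substituent on its benzylidene ring, compound 2 `O=C(N/N=C/c1ccccc1Br)c1cnccn1` carries bromo, and compound 3 `O=C(N/N=C/c1ccc(Br)cc1)c1cnccn1` carries bromo as well. In an ADME assay on J774 cells (Mus musculus) for cytotoxicity, read by MTT assay, with a stated time of 48 h, tested at 150 ug/mL (a lower number here means a stronger effect, a higher number a weaker effect of the compound at the concentration tested), compound 1 gives 100%, compound 2 gives 91% and compound 3 gives 94%. Compound 3 thus sits among values that are all within the scatter of one another; the step of a number 6 percentage points lower from compound 1 to compound 3 (within the scatter) is within the scatter, as is the step of a number 9 percentage points lower from compound 1 to compound 2 (within the scatter).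

Compound 4 `O=C(N/N=C/c1ccc(O)cc1)c1cnccn1` differs from compound 3 in one place: hydroxy in place of bromo on an aromatic carbon. Within the data shown here, no measured step introduces a hydroxy group, so the only bearing steps are those for bromo, both within the scatter. No step beyond the scatter is therefore expected in this assay. Compound 4 is estimated at 95%, in the range 82% to 100%, which is expected to mean the step of a number 1 percentage points higher from compound 3 to compound 4 (within the scatter).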

Compound 4, a percentage reported as activity, at one concentration (the size of the read-out at that concentration, not a potency): 80%
Compound 4: the middle estimate sits 15 percentage points above what was measured; measured number outside the range, below it.
By their numbers in this assay, from the lowest: compound 4; then compounds 2, 3 and 1 (each within the scatter of the next).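

At this position the read-out in this assay does depend on the group carried: replacing bromo with hydroxy gives a number 14 percentage points lower from compound 3 to compound 4 (beyond the scatter) and so moves the number beyond the scatter, whereas bromo in place of hydrogen had given only a number 6 percentage points lower from compound 1 to compound 3 (within the scatter) at the same place. Against the unsubstituted compound the hydroxy group also stands clear, with a number 20 percentage points lower from compound 1 to compound 4 (beyond the scatter) as its step, so this is the first change in the series with a readable effect at this position. No evidence at hand speaks to what lies behind this difference between hydroxy and bromo.

The compounds shown leave open whether a methoxy or an amine at this position would read like hydroxy or like bromo. They also leave open whether hydroxy elsewhere on the same ring would give a similar step, and how the effect would change at other concentrations.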